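Working notes: bromo in place of methoxy on compound 2

This account rests on a few compounds, and the source may have more. Where it says the series, first, only, none or still open, it means among the compounds named here.

- compound 1 `COc1ccc(CNc2cc(OC)c(OC)c(OC)c2)cc1Cl`: 41700 nM
- compound 2 `C/C=C/C(=O)N(Cc1ccc(OC)c(OC)c1)c1cc(OC)c(OC)c(OC)c1`: 32800 nM
- compound 3 `CCC/C=C/C(=O)N(Cc1ccc(OC)c(O)c1)c1cc(OC)c(OC)c(OC)c1`: 95 nM

All three values come from a functional assay on HCT-116 cells (Homo sapiens) for inhibition, read by MTT assay, with a stated time of 48 h; on this read-out higher numbers stand for weaker inhibition and lower numbers for stronger inhibition. Compound 2 at 32800 nM lies within the scatter of compound 1 at 41700 nM. Compound 3 at 95 nM stands far lower than both, well beyond the scatter.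

The next compound to be read is compound 4 `C/C=C/C(=O)N(Cc1ccc(OC)c(Br)c1)c1cc(OC)c(OC)c(OC)c1`. It keeps the rest of compound 2 and carries one change: bromo in place of methoxy on an aromatic carbon. This is bromo in place of methoxy on an aromatic carbon, ortho to a methoxy group and meta to a large group.

Among the measured compounds shown here, no measured pair isolates this change. Compound 3 differs from compound 2 in more than one place, so the gap between their values cannot be assigned to any single position and offers no guide to the size of this step. In this assay the expectation is therefore no step beyond the scatter, with only a slight lean towards a lower number. The estimated change is a 1.3-fold lower number from compound 2 to compound 4 (0.12 log units; within the scatter). For compound 4 the estimated value is 25000 nM, with an expected range of 7000 nM to 70000 nM.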

Compound 4, half-maximal inhibitory concentration: 2800 nM
The estimate for compound 4 lay 8.9-fold (0.95 log units) above the measured number; measured number below the stated range.
By their numbers in this assay, from the lowest: compound 3; then compound 4; then compounds 2 and 1 (each within the scatter of the next).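

In this assay, among the compounds shown here, the change from methoxy to bromo gives a 12-fold lower number from compound 2 to compound 4 (1.07 log units; beyond the scatter), the first step that can be tied to a single place. With the rest of compound 2 kept, this aromatic carbon, ortho to a methoxy group and meta to a large group, is therefore not indifferent to the group it carries. The step comes from a swap in which two heavy atoms and one hydrogen-bond acceptor leave and one heavy atom with no hydrogen-bond acceptor enters, so the methoxy group at this place is not needed for the lower number in this assay. No measurement available here accounts for the size of this step.

A single pair cannot show whether the lower number is particular to bromo or would also come with fluoro, iodo, methyl or an amine on the same carbon. On these data alone, it also remains open whether the same swap would give a step of similar size with a longer acyl chain or with other groups elsewhere on the shared core.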